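A few compounds are considered here, and "the series" means these few. Any claim that something is new, unique, unknown or untested is made for them only; others in the source may bear on it.

Measured so far in a functional assay on MDA-MB-231 cells (Homo sapiens) for cytotoxicity, read by sulforhodamine B assay, with a stated time of 72 h (a higher number here means a weaker inhibitor of growth, a lower number a stronger inhibitor of growth), for the series
- compound 1 `CC(=O)/N=C1\NCCC(c2cn(C)c3ccccc23)N1` gives 14400 nM
- compound 2 `CC(=O)/N=C1\NCCC(c2cn(C)c3ccc(Br)cc23)N1` gives 940 nM

Compound 1 holds the higher of the two numbers. Compound 3 `CC(=O)/N=C1\NCCC(c2cn(C)c3cc(Br)ccc23)N1` differs from it by bromo in place of hydrogen on an aromatic carbon in the form of bromo in place of hydrogen on an aromatic carbon. For the measured compounds named here, the only measured step bearing on this is a 15-fold lower number from compound 1 to compound 2 (1.19 log units; beyond the scatter) which is large and is also bromo in place of hydrogen, at a different aromatic carbon. A lower number is therefore expected in this assay though a smaller step is assumed, with a single precedent to go on. The expected step is a 5.8-fold lower number from compound 1 to compound 3 (0.76 log units; beyond the scatter) as estimated here. Compound 3 is expected at 2500 nM with an estimated range of 700 nM to 9000 nM around that value.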

Compound 3, concentration for 50% growth inhibition: 8020 nM
For compound 3 the middle estimate is 3.2-fold (0.51 log units) below the measured one, within the range that was stated.
By their numbers in this assay, from the lowest: compound 2; then compounds 3 and 1 (each within the scatter of the next).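

In this assay, bromo on an aromatic carbon, meta to a fused ring and para to a fused ring, gives only (a 1.8-fold lower number from compound 1 to compound 3 (0.25 log units; within the scatter)), so here the change does not separate from the unsubstituted compound. The large step (a 15-fold lower number from compound 1 to compound 2 (1.19 log units; beyond the scatter)) therefore does not hold for every aromatic carbon of the shared core, and within these two cases the outcome of bromo depends on where it sits. No measured evidence bears on the reason for this difference.

Open, from the compounds shown here alone, is whether chloro or methoxy at this carbon would also stay within the scatter. Also open, going by these compounds, is how an amine or a carboxylic acid would behave there.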